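From Methyl to Isopropyl: Estimating Compound 4

A few compounds are considered here, and "the series" means these few. Any claim that something is new, unique, unknown or untested is made for them only; others in the source may bear on it.

Compound 1, `CC(C)c1ccc(-c2nc(SCc3cn(CC(=O)NC(=O)Nc4ccccn4)nn3)nc(Nc3ccc(F)cc3)c2C#N)cc1`, gives 7250 nM in a functional assay on B16-F10 cells (Mus musculus) for inhibition, read by MTT assay, with a stated time of 72 h; on this read-out lower numbers stand for stronger inhibition and higher numbers for weaker inhibition.
Compound 2, `CC(C)c1ccc(-c2nc(SCc3cn(CC(=O)NC(=O)Nc4ccccn4)nn3)nc(Nc3cccc([N+](=O)[O-])c3)c2C#N)cc1`, gives 26400 nM in this assay.
Compound 3, `Cc1ccc(Nc2nc(SCc3cn(CC(=O)NC(=O)Nc4ccccn4)nn3)nc(-c3ccc(C(C)C)cc3)c2C#N)cc1`, gives 3060 nM in this assay.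

Compound 3 stands lowest of the three, and both a 2.4-fold lower number from compound 1 to compound 3 (0.37 log units; beyond the scatter) and an 8.6-fold lower number from compound 2 to compound 3 (0.94 log units; beyond the scatter) end at it. Compound 4, `CC(C)c1ccc(Nc2nc(SCc3cn(CC(=O)NC(=O)Nc4ccccn4)nn3)nc(-c3ccc(C(C)C)cc3)c2C#N)cc1`, differs from compound 3 by isopropyl in place of methyl on an aromatic carbon. Going by the values given here, no measured step exchanges one alkyl group for a larger one; the only steps at this ring are the two above, and each replaces the whole aryl group, so they bear on the change only loosely. A small step, most likely inside the scatter, is expected: a 1.0-fold lower number from compound 3 to compound 4 (0.01 log units; within the scatter). Compound 4 is therefore estimated at 3000 nM in this assay, with a range from 1200 nM to 8000 nM.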

Compound 4, half-maximal inhibitory concentration: 4380 nM
For compound 4 the middle estimate is 1.5-fold (0.16 log units) below the measured one, within the range that was stated.
By their numbers in this assay, from the lowest: compounds 3, 4 and 1 (each within the scatter of the next, the first and the last beyond it); then compound 2.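

Exchanging methyl for isopropyl on this aromatic carbon stays within the scatter (a 1.4-fold higher number from compound 3 to compound 4 (0.16 log units; within the scatter)), so this position accepts the larger alkyl group with no readable shift. The isopropyl group also cannot be told apart from fluoro here (a 1.7-fold lower number from compound 1 to compound 4 (0.22 log units; within the scatter)), while the 3-nitrophenyl compound remains clearly apart (a 6.0-fold lower number from compound 2 to compound 4 (0.78 log units; beyond the scatter)). Nothing available explains these results.

The compounds shown leave open whether an amine, a methoxy group or a longer alkyl chain on this carbon would move the number beyond the scatter.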